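Nitrocatechol chalcones against monoamine oxidase A: a ring swap

The source may hold more compounds than are shown below. What is called first, only, known or untested is meant among the compounds shown, and "the series" means these compounds.

Measured so far:
compound 1 `O=C(/C=C/c1nccs1)c1cc(O)c(O)c([N+](=O)[O-])c1` gives 69600 nM in an assay on isolated protein for inhibition of Amine oxidase [flavin-containing] A (Homo sapiens), read by fluorescence; on this read-out lower numbers stand for stronger inhibition and higher numbers for weaker inhibition
compound 2 `CC(=O)N1N=C(c2cc(O)c(O)c([N+](=O)[O-])c2)CC1c1ccco1` gives 98000 nM in this assay

Compound 1 has the lower of the two numbers, but its gap to compound 2 lies within the scatter, so the two cannot be ranked. Compound 3 `Cn1cc(/C=C/C(=O)c2cc(O)c(O)c([N+](=O)[O-])c2)cn1` differs from compound 1 by 1-methyl-1H-pyrazol-4-yl in place of 1,3-thiazol-2-yl on a double-bonded chain carbon bound to a double-bonded chain carbon. Among the measured compounds shown here, no measured pair shows what this swap does, so the step is expected to stay small: a 1.1-fold higher number from compound 1 to compound 3 (0.06 log units; within the scatter), in neither direction beyond the scatter. Compound 3 is therefore estimated at 80000 nM, between 25000 nM and 250000 nM.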

Compound 3, half-maximal inhibitory concentration: 51500 nM
Compound 3: middle estimate off by 1.6-fold (0.19 log units), on the high side, and the stated range covers the measured number.
By their numbers in this assay, from the lowest: compounds 3, 1 and 2 (each within the scatter of the next).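

Putting 1-methyl-1H-pyrazol-4-yl in place of 1,3-thiazol-2-yl on a double-bonded chain carbon bound to a double-bonded chain carbon gives a 1.4-fold lower number from compound 1 to compound 3 (0.13 log units; within the scatter) and so leaves the two compounds unranked. At this position, a five-membered aromatic ring with sulfur and one bearing a methyl group therefore cannot be told apart in this measurement. Nothing available explains this result.

Going by these compounds, whether any other group here could shift the number beyond the scatter remains open. An amine or a carboxylic acid on this chain, for example, lies outside the compounds shown.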